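A few compounds are considered here, and "the series" means these few. Any claim that something is new, unique, unknown or untested is made for them only; others in the source may bear on it.

Within the data shown here, in an assay (strain Wistar) for displacement of a labelled ligand from adenosine receptor A1 (Rattus norvegicus), read by scintillation counting (on this read-out higher numbers stand for weaker inhibition and lower numbers for stronger inhibition), compound 3 `O=C(Nc1nc(-c2ccccc2)nc2c1nnn2Cc1ccccc1)c1ccc([N+](=O)[O-])cc1` gives 24 nM, the second highest of the three numbers measured so far; compound 1 `O=C(Nc1nc(-c2ccccc2)nc2c1nnn2Cc1ccccc1)c1ccoc1` gives 10 nM and compound 2 `O=C(Nc1nc(-c2ccccc2)nc2c1nnn2Cc1ccccc1)c1ccc(Cl)cc1` gives 108 nM. Compound 4 `O=C(Nc1nc(-c2ccccc2)nc2c1nnn2Cc1ccccc1)c1cccc(C(F)(F)F)c1` differs from compound 3 by 3-(trifluoromethyl)phenyl in place of 4-nitrophenyl on a carbonyl carbon. Exchanges of the aryl on the carbonyl carbon gave an 11-fold higher number from compound 1 to compound 2 (1.03 log units; beyond the scatter) and a 2.4-fold higher number from compound 1 to compound 3 (0.38 log units; beyond the scatter), and the substituent exchange on the aromatic carbon gave a 4.5-fold lower number from compound 2 to compound 3 (0.65 log units; beyond the scatter). The entering group, like the 4-chlorophenyl of compound 2, counts no hydrogen-bond acceptors, whereas the leaving group counts two. A modest weakening is therefore expected; the expected step is a 2.5-fold higher number from compound 3 to compound 4 (0.40 log units; beyond the scatter). Compound 4 is estimated at 60 nM, with a range from 20 nM to 200 nM.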

Compound 4, inhibition constant: 163 nM
Estimate against measurement, compound 4: 2.7-fold (0.43 log units) below, and the stated range covers the measured number.
By their numbers in this assay, from the lowest: compound 1; then compound 3; then compounds 2 and 4 (each within the scatter of the next).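

In this assay, the exchange on the carbonyl carbon gives a 6.8-fold higher number from compound 3 to compound 4 (0.83 log units; beyond the scatter), and the furan-3-yl comparison gives a 16-fold higher number from compound 1 to compound 4 (1.21 log units; beyond the scatter), while the 4-chlorophenyl comparison gives a 1.5-fold higher number from compound 2 to compound 4 (0.18 log units; within the scatter). Of the aryl groups shown, 3-(trifluoromethyl)phenyl and 4-chlorophenyl, both counting no hydrogen-bond acceptors, therefore go unseparated, and the 4-nitrophenyl of compound 3 stands apart from both. No measurement shown here accounts for this step. Still open, from the compounds shown here alone, is what a 3-nitrophenyl or a 4-(trifluoromethyl)phenyl on the carbonyl carbon would give, and so whether the step follows the group or where it sits. Going by these compounds, an aminophenyl group at this place is equally open.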